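The source may report more compounds than this note shows. Statements on the series, on what has been measured and on what is new or still open speak of the compounds shown alone.

In a functional assay on MCF7 cells (Homo sapiens) for cytotoxicity, read by MTT assay, with a stated time of 4 h (a higher number here means a weaker inhibitor, a lower number a stronger inhibitor), compound 1 `COC(=O)C1=CO[C@@H](O[C@@H]2O[C@H](COC(c3ccccc3)(c3ccccc3)c3ccccc3)[C@@H](O)[C@H](O)[C@H]2O)[C@@H]2[C@@H](C)[C@@H](O)C[C@H]12` gives 1 ug/mL, while compound 2 `CCCCCCCCCCCC(=O)OC[C@H]1O[C@@H](O[C@@H]2OC=C(C(=O)OC)[C@H]3C[C@H](OC(C)=O)[C@H](C)[C@@H]23)[C@H](OC(C)=O)[C@@H](OC(C)=O)[C@@H]1OC(C)=O` gives 0.24 ug/mL, the lower of the two numbers and so the stronger result. Compound 3 `CCCCCCCCCCCCCCCC(=O)OC[C@H]1O[C@@H](O[C@@H]2OC=C(C(=O)OC)[C@H]3C[C@H](OC(C)=O)[C@H](C)[C@@H]23)[C@H](OC(C)=O)[C@@H](OC(C)=O)[C@@H]1OC(C)=O` is still unmeasured. It differs from compound 2 in one place: butyl in place of hydrogen on a saturated chain carbon, ten or more bonds along the chain from a carbonyl carbon. Among the measured compounds shown here, no measured pair shows what this change does. No step beyond the scatter is therefore expected in this assay, and the estimated step is a 1.3-fold higher number from compound 2 to compound 3 (0.10 log units; within the scatter). Compound 3 is expected at 0.3 ug/mL, with an estimated range of 0.1 ug/mL to 0.9 ug/mL.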

Compound 3, half-maximal inhibitory concentration: "not active" (no number reported)
The entry for compound 3 holds no number, so the estimate cannot be set against anything.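

Among the compounds shown here, compound 3 is reported as "not active" without a number in this assay, so no step from compound 2 can be read. From the compounds shown here alone, how far butyl in place of hydrogen on that chain shifts the value stays open. No supporting measurement bears on this result.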